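The compounds below may be only part of what the source reports. "The series", "measured", "known", "first", "only" and "open" are said of these compounds alone.

Measured compounds:
compound 1 `CCCC(=O)Nc1ccc(S(=O)(=O)Oc2ccccc2I)cc1` gives 9700 nM
compound 2 `CCCCCC(=O)Nc1ccc(S(=O)(=O)Oc2ccccc2I)cc1` gives 10000 nM
compound 3 `CCCNC(=O)Nc1ccc(S(=O)(=O)Oc2ccccc2C(C)C)cc1` gives 2700 nM

All three were tested in a functional assay on MCF7 cells (Homo sapiens) for antiproliferative activity, read by sulforhodamine B assay, with a stated time of 48 h; on this read-out lower numbers stand for stronger inhibition and higher numbers for weaker inhibition. Compound 1 and compound 2 share one core; compound 3 has a different core, and the difference between the two cores is not broken down here. Within the first pair the change is ethyl in place of hydrogen on a saturated chain carbon, three bonds along the chain from a carbonyl carbon, and it made a 1.0-fold higher number from compound 1 to compound 2 (0.01 log units; within the scatter). Compound 3 gives the lowest of the three numbers, and its gap to compound 1 and to compound 2 lies beyond the scatter.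

Compound 4 `CCCCCNC(=O)Nc1ccc(S(=O)(=O)Oc2ccccc2C(C)C)cc1` has not yet been measured. It carries the same kind of change relative to compound 3, namely (ethyl in place of hydrogen on a saturated chain carbon, three bonds along the chain from an amide-type nitrogen); the surroundings differ, since in compound 2 the ethyl sits three bonds along the chain from a carbonyl carbon, whereas in compound 4 it sits three bonds along the chain from an amide-type nitrogen. Because a 1.0-fold higher number from compound 1 to compound 2 (0.01 log units; within the scatter) stayed within the scatter, a similarly small step is expected on the other core, so compound 4 is estimated to show a 1.0-fold higher number from compound 3 to compound 4 (0.02 log units; within the scatter). Compound 4 is therefore expected to give about 2800 nM in this assay, likely between 1400 nM and 5600 nM.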

Compound 4, half-maximal inhibitory concentration: 4000 nM
Compound 4: the middle estimate sits 1.4-fold (0.15 log units) below what was measured, and the stated range covers the measured number.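

In this assay, ethyl in place of hydrogen on a saturated chain carbon, three bonds along the chain from an amide-type nitrogen, gave a 1.5-fold higher number from compound 3 to compound 4 (0.17 log units; within the scatter). Set beside the earlier step, this shows that the change stayed small on both cores, with no difference between the two steps that can be told from scatter: the same change on two cores in this assay, a 1.0-fold higher number (0.01 log units; within the scatter) from compound 1 to compound 2 and a 1.5-fold higher number (0.17 log units; within the scatter) from compound 3 to compound 4, 1.4-fold (0.16 log units) apart, within the scatter of two such steps. For the compounds shown here, it rests on only two pairs, however, and steps this small do not show that the chain has no bearing on the read-out, nor that the same would hold on a third core.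

The compounds shown leave open whether a longer chain, or a chain ending in an amine or a carboxylic acid, would stay as close to its parent on either core. They also leave open which of the places where the two cores differ accounts for the gap between the numbers of the two pairs.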